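This account rests on a few compounds, and the source may have more. Where it says the series, first, only, none or still open, it means among the compounds named here.

The compounds here are carboxylic acids, measured in a physicochemical assay for solubility, with a stated time of 24 h; on this read-out lower numbers stand for lower solubility and higher numbers for higher solubility. Compound 1 `Cc1ccc([C@@H](C)Oc2cc3onc(CCC(=O)O)c3cc2Cl)nc1` carries a 5-methylpyridin-2-yl group. In this assay compound 1 gives > 860 ug/mL, which is a limit of the assay rather than a number. Compound 1 thus stands at the limit of > 860 ug/mL in this assay, at which 1 of the 2 values shown sits. Compound 2 `O=C(O)CCn1c(=O)oc2cc(Cl)c(Cl)cc21`, built on a different core, gives 270 ug/mL in this assay. For the measured compounds named here, no two measured compounds differ in only one place, so no measured step can be drawn between them. Compound 3 `Cc1ccc([C@@H](C)Oc2cc3onc(CCC(=O)O)c3cc2Cl)nn1` has not yet been measured; it differs from compound 1 by 6-methylpyridazin-3-yl in place of 5-methylpyridin-2-yl on a saturated chain carbon bound to an oxygen on an aromatic ring and a saturated chain carbon. The step that the limit leaves unreadable from compound 1 to compound 3 is expected to stay within the scatter, because compound 1 already sits at the limit of > 860 ug/mL in this assay, at which 1 of the 2 values shown sits, and the result for the new compound is likely to be a limit again. The expected solubility for compound 3 is 900 ug/mL, with a range from 500 ug/mL to 1800 ug/mL.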

Compound 3, solubility: 230 ug/mL
Beside the measured number, compound 3's estimate is 3.9-fold (0.59 log units) above it, and the stated range ends above it.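

Compared with the earlier compounds, which offered no step at all, this is the first change in one place, and it shows that the group on this saturated chain carbon matters for the read-out. In this assay, 6-methylpyridazin-3-yl in place of 5-methylpyridin-2-yl gives an at least 3.7-fold lower number from compound 1 to compound 3 (0.57 log units; beyond the scatter), and the ring change amounts to one ring carbon replaced by a nitrogen. The step has no fixed size, since compound 1 is known only as a limit of the assay and not as a number: the limit of > 860 ug/mL in this assay, at which 1 of the 3 values shown sits.

On these data alone, what remains open is how a phenyl ring or a pyrimidine ring at the same place would compare in this assay. Also open, as far as these compounds go, is whether a similar step would appear on a different core, and no measurement here explains why the number falls.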